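The source may hold more compounds than are shown below. What is called first, only, known or untested is meant among the compounds shown, and "the series" means these compounds.

Compound 1 `COc1cccc(OC)c1OCCNCCOc1ccccc1OCc1ccccc1` carries a plain benzyloxy group on one of its aromatic rings. In a functional assay on PC-3 cells (Homo sapiens) for cytotoxicity, read by sulforhodamine B assay (a higher number here means that more compound is tolerated, a lower number that less compound is tolerated), compound 1 gives 193000 nM, the highest of the three numbers recorded so far. Compound 2 `COc1cccc(OC)c1OCCNCCOc1ccccc1OCc1ccc(Cl)cc1` adds chloro in place of hydrogen on an aromatic carbon, and in this assay compound 2 gives 52500 nM; the step of a 3.7-fold lower number from compound 1 to compound 2 (0.57 log units; beyond the scatter) is modest but beyond the scatter. Compound 3 `COc1cccc(COc2ccccc2OCCNCCOc2c(OC)cccc2OC)c1` adds methoxy in place of hydrogen on an aromatic carbon, and compound 3 gives 61700 nM; the step of a 3.1-fold lower number from compound 1 to compound 3 (0.50 log units; beyond the scatter) is of the same kind. Between these two substituted compounds the step of a 1.2-fold higher number from compound 2 to compound 3 (0.07 log units; within the scatter) lies within the scatter.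

Compound 4 `CCOc1ccc(COc2ccccc2OCCNCCOc2c(OC)cccc2OC)cc1` differs from compound 1 as follows: ethoxy in place of hydrogen on an aromatic carbon. The ethoxy enters on an aromatic carbon para to a large group, on the same ring where chloro and methoxy entered in compound 2 and compound 3. Both of those steps, a 3.7-fold lower number from compound 1 to compound 2 (0.57 log units; beyond the scatter) and a 3.1-fold lower number from compound 1 to compound 3 (0.50 log units; beyond the scatter), bear on this change and both lowered the number by a modest margin. A step of similar size, downward, is therefore expected in this assay, namely a 3.2-fold lower number from compound 1 to compound 4 (0.51 log units; beyond the scatter). On that basis compound 4 is estimated at 60000 nM, with a range from 25000 nM to 150000 nM.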

Compound 4, concentration lethal to 50% of the cells: 51300 nM
Compound 4: middle estimate off by 1.2-fold (0.07 log units), on the high side, and the stated range covers the measured number.
By their numbers in this assay, from the lowest: compounds 4, 2 and 3 (each within the scatter of the next); then compound 1.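

In this assay, ethoxy on an aromatic carbon para to a large group gives a 3.8-fold lower number from compound 1 to compound 4 (0.58 log units; beyond the scatter) and so joins chloro and methoxy as a third group that lowers the number by a modest margin, with no compound shown going against this. The substituted compounds do not separate from one another: the change from 3-methoxyphenyl to 4-ethoxyphenyl gives a 1.2-fold lower number from compound 3 to compound 4 (0.08 log units; within the scatter) and the change from chloro to ethoxy gives a 1.0-fold lower number from compound 2 to compound 4 (0.01 log units; within the scatter), and both steps lie within the scatter. Among these compounds, then, a group on this ring goes with a number beyond the scatter of compound 1, while the choice among chloro, methoxy and ethoxy makes no readable difference, and nothing measured here offers an explanation for either observation.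

The compounds shown leave open whether a group of another kind on this ring, such as an amine or a carboxylic acid, would give a similar step. They also leave open whether a longer chain in place of ethoxy would lower the number further, and whether the same group would give the same step at a different place on the ring.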